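The compounds below may be only part of what the source reports. "The series", "measured", "known", "first", "only" and "open" are said of these compounds alone.

Three compounds have numbers in a functional assay on SK-MEL-5 cells (Homo sapiens) for antiproliferative activity; a higher number here means a weaker inhibitor of growth, a lower number a stronger inhibitor of growth. Compound 1 `Cc1ccc2c(O)cc(-c3cccc(Cl)c3)nc2n1` gives 31.6 nM, compound 2 `Cc1cnc2[nH]c(-c3cccc(Cl)c3)cc(=O)c2c1` gives 70.8 nM, and compound 3 `Cc1cc(C)c2c(O)cc(-c3ccc4ccccc4c3)nc2n1` gives 2190 nM. Compound 2 thus stands in the middle of the three, with a gap beyond the scatter on either side. Compound 4 `Cc1cnc2[nH]c(-c3cccc(F)c3)cc(=O)c2c1` has not yet been measured and departs from compound 2 in one place: fluoro in place of chloro on an aromatic carbon, with fluoro in place of chloro on an aromatic carbon. Within the data shown here, no measured pair shows this change, so the expectation in this assay is tentative: a small move to a higher number, possibly no larger than the scatter. The expected change is a 1.6-fold higher number from compound 2 to compound 4 (0.19 log units; within the scatter). For compound 4 the estimate is 110 nM, within an expected range of 35 nM to 350 nM.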

Compound 4, concentration for 50% growth inhibition: 28.2 nM
For compound 4 the middle estimate is 3.9-fold (0.59 log units) above the measured one; the measured number lies below the stated range.
By their numbers in this assay, from the lowest: compounds 4 and 1 (each within the scatter of the next); then compound 2; then compound 3.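

In this assay, fluoro in place of chloro on the aromatic carbon meta to a large group gives a 2.5-fold lower number from compound 2 to compound 4 (0.40 log units; beyond the scatter), a modest step beyond the scatter. Among these compounds, this is the first pair here that differs in one place, and it shows that this position is not indifferent to which of the two halogens it carries, with fluoro giving the lower number. Nothing available explains the direction of this step.

On these data alone, whether a methoxy or trifluoromethyl group at this position would move the number further remains open. So does whether the same exchange would give a similar step on the core of compound 1.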